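From 3-hydroxypropyl to propyl on a shared core

A few compounds are considered here, and "the series" means these few. Any claim that something is new, unique, unknown or untested is made for them only; others in the source may bear on it.

In a functional assay on A549 cells (Homo sapiens) for antiproliferative activity, read by sulforhodamine B assay, with a stated time of 48 h (on this read-out higher numbers stand for weaker inhibition of growth and lower numbers for stronger inhibition of growth), compound 1 `COc1ccc(Nc2nc(NC3CCCC3)c3ccccc3n2)cc1` gives 10100 nM, and compound 2 `COc1ccc(Nc2nc(NCCCO)c3ccccc3n2)cc1` gives 15200 nM. With only these two numbers to compare, compound 2 sits within the scatter of compound 1, so the two cannot be ranked. Compound 3 `CCCNc1nc(Nc2ccc(OC)cc2)nc2ccccc12` has not yet been measured. It differs from compound 2 by hydrogen in place of hydroxy on a saturated chain carbon, three bonds along the chain from a nitrogen on an aromatic ring, so 3-hydroxypropyl becomes propyl. Among the measured compounds shown here, only one measured step touches this chain, the swap of cyclopentyl for 3-hydroxypropyl. Since that swap amounted to a 1.5-fold higher number from compound 1 to compound 2 (0.18 log units; within the scatter), no step beyond the scatter is expected in this assay, although a single step is thin evidence. The estimated step is a 1.2-fold lower number from compound 2 to compound 3 (0.07 log units; within the scatter). Compound 3 is expected at 13000 nM, with an estimated range from 6500 nM to 26000 nM.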

Compound 3, concentration for 50% growth inhibition: 3530 nM
Compound 3: middle estimate off by 3.7-fold (0.57 log units), on the high side; measured number outside the range, below it.
By their numbers in this assay, from the lowest: compound 3; then compounds 1 and 2 (each within the scatter of the next).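

Taking the hydroxy off the chain gives a 4.3-fold lower number from compound 2 to compound 3 (0.63 log units; beyond the scatter) in this assay and is the first step at this position to lie beyond the scatter, so the end of this chain matters more than the earlier swap suggested. The propyl chain also separates from the ring, with a 2.9-fold lower number from compound 1 to compound 3 (0.46 log units; beyond the scatter) for propyl in place of cyclopentyl, while 3-hydroxypropyl and cyclopentyl could not be ranked. Nothing measured here explains either step.

Whether the stronger inhibition of growth belongs to propyl itself or would extend to other chains without a hydroxy stays open, as propyl is the only such chain shown. A longer chain such as butyl, or an amine in place of the hydroxy at the chain end, would help to settle how far this result reaches.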